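Swapping a Sulfonyl for a Chloropyrimidine at the Ring Amine

This account rests on a few compounds, and the source may have more. Where it says the series, first, only, none or still open, it means among the compounds named here.

Compound 1 `CCCS(=O)(=O)N1CC=C(c2ccc3c(c2)CC(C2CCN(C(=O)OC(C)C)CC2)O3)CC1` and compound 2 `CCCS(=O)(=O)N1CC=C(c2ccc3c(c2)CC(C2CCN(S(=O)(=O)CCC)CC2)O3)CC1` share one core and differ only in the group on an amine nitrogen in a ring. In a functional assay on HEK293 cells for agonist activity at Glucose-dependent insulinotropic receptor (Homo sapiens), read by cAMP accumulation, with a stated time of 60 min (on this read-out higher numbers stand for an effect only at larger amounts of compound and lower numbers for an effect already at smaller amounts), compound 1 gives 103 nM, while compound 2 gives 1000 nM. That change is the step of a 9.7-fold higher number from compound 1 to compound 2 (0.99 log units; beyond the scatter), and in this assay compound 2 stands highest of the two numbers measured. Compound 3 `CCCS(=O)(=O)N1CC=C(c2ccc3c(c2)CC(C2CCN(c4ncc(Cl)cn4)CC2)O3)CC1` has not yet been measured; it differs from compound 2 in that (5-chloropyrimidin-2-yl in place of propylsulfonyl on an amine nitrogen in a ring). Among the compounds with values here, only one measured step touches this position, a 9.7-fold higher number from compound 1 to compound 2 (0.99 log units; beyond the scatter), and it shows that the group on this nitrogen can move the number by a noticeable amount. Within the data shown here, no measured pair shows an aromatic ring at this nitrogen, so the direction remains uncertain. For compound 3 a move back towards lower numbers is expected, a 5.0-fold lower number from compound 2 to compound 3 (0.70 log units; beyond the scatter). Compound 3 is therefore estimated at 200 nM, with a range from 40 nM to 1000 nM.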

Compound 3, half-maximal effective concentration: 78 nM
Compound 3: the middle estimate sits 2.6-fold (0.41 log units) above what was measured; the range from low to high includes it.
By their numbers in this assay, from the lowest: compounds 3 and 1 (each within the scatter of the next); then compound 2.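

In this assay, the position gains its first aromatic ring, and 5-chloropyrimidin-2-yl in place of propylsulfonyl gives a large step (a 13-fold lower number from compound 2 to compound 3 (1.11 log units; beyond the scatter)) that takes the number back down. The step to the other comparison group (a 1.3-fold lower number from compound 1 to compound 3 (0.12 log units; within the scatter)) lies within the scatter, so 5-chloropyrimidin-2-yl and isopropoxycarbonyl cannot be told apart here, even though one carries an aromatic ring and the other does not. Among these three groups, propylsulfonyl alone stands apart from the others, and nothing available here speaks to the reason for these differences.

Still open, as far as these compounds go, is whether the chlorine matters, which a pyrimidin-2-yl group with hydrogen, methyl or nitrile in its place would test. A phenyl ring on this amine nitrogen would show whether the ring nitrogens of the pyrimidine matter.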